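From methoxyphenyl to iodophenyl on a shared core

The source may report more compounds than this note shows. Statements on the series, on what has been measured and on what is new or still open speak of the compounds shown alone.

Compound 1 `COc1cccc(-c2nc3c(c(C)nn3-c3ccccc3)c(-c3ccccc3O)c2C#N)c1` was examined in an ADME assay on BJ cells (Homo sapiens) for cytotoxicity, with a stated time of 72 h; on this read-out higher numbers stand for an effect only at larger amounts of compound and lower numbers for an effect already at smaller amounts. In this assay compound 1 gives > 23000 nM, which is a limit of the assay and not a number. Compound 2 `CCc1ccc(-c2nc3c(c(C)nn3-c3ccccc3)c(-c3ccccc3C(=O)O)c2C#N)cc1` gives > 20000 nM in this assay, again a limit rather than a number. Compound 3 `CCc1ccc(-c2nc3c(c(C)nn3-c3ccccc3)c(-c3ccccc3OC(F)(F)F)c2C#N)cc1` gives > 20000 nM in this assay, also a limit. The only measured step between two of these compounds is a step that the two limits leave unreadable from compound 2 to compound 3. Compound 4 `Cc1nn(-c2ccccc2)c2nc(-c3ccc(I)cc3)c(C#N)c(-c3ccccc3O)c12` has not yet been measured in this assay. It differs from compound 1 in one place: 4-iodophenyl in place of 3-methoxyphenyl on an aromatic carbon. No measured step touches this change, and all three known values sit at limits, as shown by the limit of > 20000 nM in this assay, at which 2 of the 3 values shown sit, and (the limit of > 23000 nM in this assay, at which 1 of the 3 values shown sits). Compound 4 is therefore expected to sit at a limit as well, with no step beyond the scatter to be read. The expected step that the limit leaves unreadable from compound 1 to compound 4 carries this. For compound 4 the estimate in this assay is 25000 nM, from 8000 nM to 60000 nM.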

Compound 4, half-maximal effective concentration: 19000 nM
Estimate against measurement, compound 4: 1.3-fold (0.12 log units) above; the range from low to high includes it.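

In this assay compound 4 gives 19000 nM, the only actual number among the compounds shown. Placing 4-iodophenyl in place of 3-methoxyphenyl on this aromatic carbon, next to the ring nitrogen and ortho to a cyano group, gives an at least 1.2-fold lower number from compound 1 to compound 4 (0.08 log units; that floor lies within the scatter), so the change is readable only as a floor, and that floor establishes no difference beyond the usual scatter. The value of compound 1 is a limit of the assay and not a number, which leaves the true size of this step unknown: the limit of > 23000 nM in this assay, at which 1 of the 4 values shown sits.

Within the data shown here, the steps that rest on limits on both sides cannot be read, and that includes the one linking compound 2 and compound 3: the limit of > 20000 nM in this assay, at which 2 of the 4 values shown sit. Whether a bromophenyl or an aminophenyl group at this place would also give a number rather than a limit stays open.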